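The compounds below may be only part of what the source reports. "The series", "measured", "known", "first", "only" and "open" are said of these compounds alone.

Compound 2 `[N-]=[N+]=NCc1cc(=O)n(-c2ccccc2)s1` gives 58000 nM in an assay for inhibition of histone acetyltransferase KAT2B (Homo sapiens) (a higher number here means a weaker inhibitor, a lower number a stronger inhibitor), and compound 1 `O=c1cc(CO)sn1-c1ccccc1` gives 109000 nM, the two numbers lying within the scatter of each other. Within the data shown here, the one measured step, a 1.9-fold lower number from compound 1 to compound 2 (0.27 log units; within the scatter), did not leave the scatter. Compound 3 `Cc1cc(=O)n(-c2ccccc2)s1` differs from compound 2 by hydrogen in place of azido on a saturated chain carbon bound to an aromatic carbon, a change at the same place as that measured step. Among the measured compounds shown here, since the only step that bears on it moved the number so little, no shift beyond the scatter is expected, and the expected step of a 1.2-fold higher number from compound 2 to compound 3 (0.08 log units; within the scatter) is correspondingly small. Compound 3 is therefore estimated at 70000 nM, with a range from 25000 nM to 200000 nM.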

Compound 3, half-maximal inhibitory concentration: > 200000 nM
Compound 3: a limit, no number (the forecaster's own chance of this, stated with the estimate: 15%); middle value at least 2.8-fold (0.45 log units) away from the limit.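

In this assay compound 3 gives > 200000 nM, which is a limit of the assay and not a number. At this saturated chain carbon bound to an aromatic carbon, hydrogen in place of azido gives an at least 3.4-fold higher number from compound 2 to compound 3 (0.53 log units; beyond the scatter), so the number does respond to the group placed here, which the earlier step within the scatter could not show. Hydrogen in place of hydroxy gives an at least 1.8-fold higher number from compound 1 to compound 3 (0.26 log units; that floor lies within the scatter), so that comparison separates the two groups no further.

As far as these compounds go, how far compound 3 lies past its limit stays open. So does whether an amine or a carboxylic acid on this carbon would give a lower number than azido.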